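Swapping the amide aryl group on a sulfoxide-linked quinazoline

This account rests on a few compounds, and the source may have more. Where it says the series, first, only, none or still open, it means among the compounds named here.

Measured so far:
Compound 1, `COc1cc2nc(SCC(=O)Nc3ccc(S(N)(=O)=O)cc3)nc(Nc3c(Cl)cc(/C=C/C#N)cc3Cl)c2cc1OC`, gives 116000 nM in an ADME assay on MT4 cells (Homo sapiens) for cytotoxicity, read by MTT assay, with a stated time of 5 days; on this read-out higher numbers stand for lower toxicity in this test and lower numbers for higher toxicity in this test.
Compound 2, `COc1cc2nc([S+]([O-])CC(=O)Nc3ccccc3F)nc(Nc3c(Cl)cc(/C=C/C#N)cc3Cl)c2cc1OC`, gives > 208000 nM in this assay, which is a limit of the assay rather than a number.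

Compound 2 therefore stands at the limit described by the limit of > 208000 nM in this assay, at which 1 of the 2 values shown sits, where one of the two measured values sits. Compound 3, `COc1cc2nc([S+]([O-])CC(=O)Nc3ccc(C#N)cc3)nc(Nc3c(Cl)cc(/C=C/C#N)cc3Cl)c2cc1OC`, has not been measured. It differs from compound 2 in one place: 4-cyanophenyl in place of 2-fluorophenyl on an amide-type nitrogen. Among the compounds with values here, no measured pair shows what this change does on its own. For compound 3 the expected step of an at least 1.1-fold lower number from compound 2 to compound 3 (0.06 log units; that floor lies within the scatter) is small, within the usual scatter, so that compound 3 is expected to show low toxicity, close to the limit, because compound 2 sits at > 208000 nM. Compound 3 is estimated at 180000 nM, with a range from 70000 nM to 400000 nM.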

Compound 3, half-maximal cytotoxic concentration: >= 188000 nM
Compound 3: only a limit was reported (the forecaster's own chance of this, stated with the estimate: 50%); middle value at least 1.0-fold (0.01 log units) from the limit.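

Within the data shown here, compound 2 and compound 3 each carry only a limit of the assay in this assay, so no step between them can be read. The compounds shown leave open how far 4-cyanophenyl in place of 2-fluorophenyl shifts the half-maximal cytotoxic concentration on its own.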